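The source may hold more compounds than are shown below. What is called first, only, known or untested is meant among the compounds shown, and "the series" means these compounds.

Within the data shown here, compound 2 `COc1cc(NC(C)CCCNC(=O)NNC(=O)Nc2ccc(Cl)cc2)c2ncccc2c1` stands at the highest of the two numbers so far: in a functional assay on L1210 cells (Mus musculus) for inhibition, read by MTT assay, with a stated time of 72 h (on this read-out lower numbers stand for stronger inhibition and higher numbers for weaker inhibition), compound 2 gives 58000 nM, whereas compound 1 `COc1cc(NC(C)CCCNC(=O)Nc2cccc(Cl)c2)c2ncccc2c1` gives 17000 nM. Among the measured compounds shown here, the one measured step, a 3.4-fold higher number from compound 1 to compound 2 (0.53 log units; beyond the scatter), weakens inhibition modestly.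

Compound 3 `COc1cc(NC(C)CCCNC(=O)Nc2cccc(C(F)(F)F)c2)c2ncccc2c1` differs from compound 2 by 3-(trifluoromethyl)phenyl in place of ((4-chlorophenyl)carbamoyl)amino on an amide-type nitrogen. This change undoes much of what the step from compound 1 to compound 2 introduced, returning to a single substituted phenyl ring on that amide-type nitrogen, now bearing trifluoromethyl rather than chlorine. That measured step therefore bears on it directly, in reverse: a return of similar size toward the number of compound 1 is the natural expectation, so compound 3 is expected to sit close to compound 1 in this assay.

The expected step is a 3.4-fold lower number from compound 2 to compound 3 (0.53 log units; beyond the scatter). The estimate for compound 3 in this assay is 17000 nM, within a range from 7000 nM to 45000 nM.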

Compound 3, half-maximal inhibitory concentration: 9200 nM
For compound 3 the middle estimate is 1.8-fold (0.27 log units) above the measured one; low and high end bracket the measured number.
By their numbers in this assay, from the lowest: compounds 3 and 1 (each within the scatter of the next); then compound 2.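

In this assay, replacing the ((4-chlorophenyl)carbamoyl)amino group on the amide-type nitrogen with 3-(trifluoromethyl)phenyl gives a 6.3-fold lower number from compound 2 to compound 3 (0.80 log units; beyond the scatter), so the number falls well beyond the scatter once a substituted phenyl ring sits directly on that nitrogen. Trifluoromethyl in place of chloro on the aromatic carbon gives a 1.8-fold lower number from compound 1 to compound 3 (0.27 log units; within the scatter), so this assay does not separate these two groups at this place. Nothing measured here accounts for either step.

On these data alone, whether an amine or a carboxylic acid on the aromatic carbon would keep the number of compound 3 remains open. So does whether a benzyl group on the amide-type nitrogen, in place of 3-(trifluoromethyl)phenyl, would behave like the phenyl rings of compound 1 and compound 3.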